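Oxime O-methylation in the compound 2 series

The source may report more compounds than this note shows. Statements on the series, on what has been measured and on what is new or still open speak of the compounds shown alone.

Measured compounds:
compound 1, `O/N=C(/CCN1CCN(c2ncccn2)CC1)c1ccccc1`, gives 69 nM in a functional assay on HEK293 cells with D(4) dopamine receptor (Homo sapiens) as the target, read by FLIPR; a lower number here means that less compound is needed, a higher number that more compound is needed for the effect.
compound 2, `O/N=C(/CCCN1CCN(c2ccccn2)CC1)c1ccc(F)cc1`, gives 59.3 nM in this assay.

Among the compounds with values here, compound 2 sits together with compound 1 on the numbers so far: the gap between them lies within the usual scatter, so the two cannot be told apart and neither is to be called the more potent. Compound 3, `CO/N=C(/CCCN1CCN(c2ccccn2)CC1)c1ccc(F)cc1`, is the next case and has not yet been measured in this assay. The change from compound 2 is methyl in place of hydrogen on an oxygen; the same difference, read one bond further out, is hydroxy to methoxy. Within the data shown here, no step between measured compounds covers this change, and there is nothing among the measured pair that bears on it. The expectation is therefore a step of modest size, if any, in the direction of a somewhat higher number, with a real chance that it stays within the scatter. On that basis compound 3 is expected to give about 95 nM in this assay, with a range from 25 nM to 360 nM, which corresponds to an estimated step of a 1.6-fold higher number from compound 2 to compound 3 (0.20 log units; within the scatter).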

Compound 3, half-maximal effective concentration: 33.5 nM
For compound 3 the middle estimate is 2.8-fold (0.45 log units) above the measured one; measured number inside the range.
By their numbers in this assay, from the lowest: compounds 3, 2 and 1 (each within the scatter of the next, the first and the last beyond it).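

In this assay, within the data shown here, the step of a 1.8-fold lower number from compound 2 to compound 3 (0.25 log units; within the scatter) is the first reading at this oxygen, and it places the methoxy and hydroxy forms of the oxime within the scatter of each other, so the two cannot be told apart. Methyl in place of hydrogen on this oxygen is therefore tolerated in this series: compound 3 gives 33.5 nM, and the hydrogen on the oxygen is not needed to keep the number at the level of compound 2. Nothing measured alongside these compounds gives a reason for the result, so the reading stays a plain observation on one matched pair.

Going by these compounds, whether this tolerance extends beyond a single carbon remains open: an ethyl, a benzyl or a carboxymethyl group on the same oxygen could stay at this level or could leave it. Also open, on these data alone, is whether methyl in place of hydrogen on the oxime oxygen reads the same on the core of compound 1, which differs from compound 2 in more than one place and so gives no comparison here.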